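Ortho-substituent series on a shared imidazoline ether core

A few compounds are considered here, and "the series" means these few. Any claim that something is new, unique, unknown or untested is made for them only; others in the source may bear on it.

Measured so far in a functional assay on CHO cells for agonist activity at Alpha-2B adrenergic receptor (Homo sapiens); on this read-out lower numbers stand for an effect already at smaller amounts and higher numbers for an effect only at larger amounts of compound:
compound 1 `CC(Oc1ccccc1Br)C1=NCCN1` — 316 nM
compound 2 `CCc1ccccc1OC(C)C1=NCCN1` — 10000 nM
compound 3 `COc1ccccc1OC(C)C1=NCCN1` — 100000 nM

Compound 3 gives the highest number of the three in this assay; its nearest neighbour is compound 2, as the step of a 10-fold higher number from compound 2 to compound 3 (1.00 log units; beyond the scatter) shows, and the widest gap is to compound 1, a 320-fold higher number from compound 1 to compound 3 (2.50 log units; beyond the scatter). The difference between compounds 1 and 2 is the step of a 32-fold higher number from compound 1 to compound 2 (1.50 log units; beyond the scatter). All three steps lie beyond the scatter, so the substituent on the aromatic carbon sets the number across a wide span.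

Compound 4 `CC(=O)c1ccccc1OC(C)C1=NCCN1` is not yet measured. It differs from compound 3 by acetyl in place of methoxy on an aromatic carbon. Among the compounds with values here, no measured step involves an acetyl, so none bears directly on this change. Within the data shown here, the only steps that touch methoxy are the two that remove it, and both lower the number. Compound 4 is therefore expected to return part of the way toward compound 2, an estimated step of a 3.3-fold lower number from compound 3 to compound 4 (0.52 log units; beyond the scatter) in this assay. The estimate for compound 4 is 30000 nM with a range from 5000 nM to 150000 nM.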

Compound 4, half-maximal effective concentration: 295 nM
Beside the measured number, compound 4's estimate is 100-fold (2.01 log units) above it; measured number outside the range, below it.
By their numbers in this assay, from the lowest: compounds 4 and 1 (each within the scatter of the next); then compound 2; then compound 3.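

With acetyl on this aromatic carbon, this assay shows a 340-fold lower number from compound 3 to compound 4 (2.53 log units; beyond the scatter) and a 34-fold lower number from compound 2 to compound 4 (1.53 log units; beyond the scatter) as large steps, the first of them as wide as the whole span seen before. Methoxy and acetyl each count one hydrogen-bond acceptor yet give values far apart, so that count alone does not set the number at this position. The step of a 1.1-fold lower number from compound 1 to compound 4 (0.03 log units; within the scatter) leaves bromo and acetyl indistinguishable here, so a low number at this place is no longer tied to bromo alone.

Nothing available explains these differences. Still open, from the compounds shown here alone, is whether other groups at this position, such as a carboxylic acid, a methyl ester or an amine, also give numbers as low as those of bromo and acetyl, or fall back toward those of ethyl and methoxy.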